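A few compounds are considered here, and "the series" means these few. Any claim that something is new, unique, unknown or untested is made for them only; others in the source may bear on it.

Notes on the series. Compound 1 `CCC(CC)n1c(-c2ccc(OCc3c(-c4c(Cl)cccc4Cl)noc3C(C)C)cc2)nc2ccc(C(=O)O)cc21` gives in an assay on Huh-7 cells for agonist activity at Bile acid receptor (Homo sapiens), read by a luciferase reporter (a lower number here means that less compound is needed, a higher number that more compound is needed for the effect), a value of 0.8 nM. Compound 2 `CC(C)c1onc(-c2c(Cl)cccc2Cl)c1COc1ccc(-c2nc3ccc(C(=O)O)cc3n2CC2CC2)cc1` gives in this assay a value of 19.4 nM. Compound 3 `CC(=O)N1CCC(n2c(-c3ccc(OCc4c(-c5c(Cl)cccc5Cl)noc4C(C)C)cc3)nc3ccc(C(=O)O)cc32)CC1` gives in this assay a value of 1430 nM. For the measured compounds named here, compound 3 therefore stands at the highest number of the three measured so far: a 74-fold higher number from compound 2 to compound 3 (1.87 log units; beyond the scatter) and a 1800-fold higher number from compound 1 to compound 3 (3.25 log units; beyond the scatter). The three compounds differ only in the group on the aromatic nitrogen of the shared core.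

Compound 4 `CC(=O)C1CCC(Cn2c(-c3ccc(OCc4c(-c5c(Cl)cccc5Cl)noc4C(C)C)cc3)nc3ccc(C(=O)O)cc32)CC1` carries the next change at that same position: (4-acetylcyclohexyl)methyl in place of 1-acetylpiperidin-4-yl on an aromatic nitrogen. All three measured steps concern this position and all were large: a 24-fold higher number from compound 1 to compound 2 (1.38 log units; beyond the scatter), a 1800-fold higher number from compound 1 to compound 3 (3.25 log units; beyond the scatter) and a 74-fold higher number from compound 2 to compound 3 (1.87 log units; beyond the scatter). Going by the values given here, no measured step exchanges one six-membered ring for another here, and the acetyl carbonyl is kept, so the new step is expected to remain within the span these three steps set. A lower number than compound 3 is expected, of moderate size: a 5.7-fold lower number from compound 3 to compound 4 (0.76 log units; beyond the scatter). For compound 4 the estimate in this assay is 250 nM, with a range from 50 nM to 1250 nM.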

Compound 4, half-maximal effective concentration: 1170 nM
Beside the measured number, compound 4's estimate is 4.7-fold (0.67 log units) below it; low and high end bracket the measured number.
By their numbers in this assay, from the lowest: compound 1; then compound 2; then compounds 4 and 3 (each within the scatter of the next).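

In this assay, a 1.2-fold lower number from compound 3 to compound 4 (0.09 log units; within the scatter): on this aromatic nitrogen, replacing the 1-acetylpiperidin-4-yl group with (4-acetylcyclohexyl)methyl, a ring of carbon only, keeps the two compounds within the scatter of each other. Both groups carry an acetyl on a six-membered non-aromatic ring, and both compounds stand well away from the compounds with smaller groups lacking an acetyl, with a 60-fold higher number from compound 2 to compound 4 (1.78 log units; beyond the scatter) and a 1500-fold higher number from compound 1 to compound 4 (3.17 log units; beyond the scatter). No measurement at hand gives a reason for these numbers.

Going by these compounds, whether the high numbers go with the acetyl or with the six-membered ring stays open, and a plain cyclohexylmethyl group on this nitrogen would separate the two. An amine or a hydroxyl in place of the acetyl would show whether that group can be changed at all.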